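This account rests on a few compounds, and the source may have more. Where it says the series, first, only, none or still open, it means among the compounds named here.

Measured in a toxicity assay on MT4 cells (Homo sapiens) for cytotoxicity, read by MTT assay; a lower number here means that less compound is tolerated, a higher number that more compound is tolerated:
compound 1 `Cc1cc(-c2ccc(F)cc2)cc(C)c1Oc1cc(N)nc(Nc2ccc(C#N)cc2)n1`: 23100 nM
compound 2 `Cc1cc(-c2ccc(Cl)cc2)cc(C)c1Oc1cc(N)nc(Nc2ccc(C#N)cc2)n1`: 21500 nM

Among the compounds with values here, compound 2 lies within the usual scatter of compound 1, the only other compound measured, so the two cannot be ranked against each other. The next compound, compound 3 `COc1ccccc1-c1cc(C)c(Oc2cc(N)nc(Nc3ccc(C#N)cc3)n2)c(C)c1`, carries 2-methoxyphenyl in place of 4-chlorophenyl on an aromatic carbon.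

Within the data shown here, only one measured step bears on this change: a 1.1-fold lower number from compound 1 to compound 2 (0.03 log units; within the scatter), with chloro in place of fluoro on an aromatic carbon. It is a weak guide, since swapping chloro for fluoro is a much narrower change than exchanging one whole group for another. Among the measured compounds shown here, no measured compound carries 2-methoxyphenyl, so the data give no sign of a shift in either direction. The expectation therefore stays close to compound 2 at 21500 nM, with no change beyond the scatter in this assay, though with a wide margin of doubt.

The expected step is a 1.0-fold lower number from compound 2 to compound 3 (0.01 log units; within the scatter).

Compound 3 is estimated at 21000 nM, with an expected range from 8000 nM to 55000 nM.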

Compound 3, half-maximal cytotoxic concentration: 21800 nM
For compound 3 the middle estimate is 1.0-fold (0.02 log units) below the measured one, within the range that was stated.
By their numbers in this assay, from the lowest: compounds 2, 3 and 1 (each within the scatter of the next).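

Swapping one halogen for another on the same phenyl ring was a narrow change, whereas this one replaces 4-chlorophenyl with 2-methoxyphenyl, which has one more heavy atom, moves the substituent on the ring to a different place and brings in a hydrogen-bond acceptor. Even so, this assay shows a 1.0-fold higher number from compound 2 to compound 3 (0.01 log units; within the scatter), and the comparison with the fluorinated analogue gives a 1.1-fold lower number from compound 1 to compound 3 (0.03 log units; within the scatter). At this position, para to a large group on the central ring, all three aromatic groups therefore give numbers that cannot be told apart, and no measurement shown here accounts for this sameness.

All three compounds carry a substituted phenyl ring at this position, so they leave open whether a group of a different kind, such as an amine, a carboxylic acid or a longer chain, would stay within the scatter or move the number beyond it. They also leave open how far this tolerance extends across other phenyl substituents, since only fluoro, chloro and methoxy appear here.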